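The source may report more compounds than this note shows. Statements on the series, on what has been measured and on what is new or still open speak of the compounds shown alone.

Compounds measured in an assay on Sf9 cells for inhibition of protein deacetylase HDAC6 (Homo sapiens), read by fluorescence, with a stated time of 40 min, tested at 100 nM; on this read-out lower numbers stand for less inhibition and higher numbers for more inhibition at the one concentration tested (going by the name of the read-out):
- compound 1, `O=C(NO)c1ccc(NCc2nc(-c3ccco3)nn2-c2ccccc2)cc1`: 59.9%
- compound 2, `Cc1ccc(-n2nc(-c3ccccc3)nc2CNc2ccc(C(=O)NO)cc2)cc1C`: 53%
- compound 3, `NC(=O)c1ccc(NCc2nc(-c3ccccc3)nn2-c2ccccc2)cc1`: -4.4%

Compound 1 gives the highest of the three numbers in this assay, yet compound 2, whose number is within the scatter of it, cannot be set below it on these data. Compound 3, which carries a plain carboxamide where compound 1 carries a hydroxamic acid, falls far beyond the scatter below both.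

The unmeasured compound 4, `O=C(NO)c1ccc(NCc2nc(-c3ccsc3)nn2-c2ccccc2)cc1`, keeps the hydroxamic acid and the shared core of compound 1 and differs from it in one place: thiophen-3-yl in place of furan-2-yl on an aromatic carbon. Within the data shown here, the change leaves the hydroxamic acid untouched, and the only comparison at hand for a change of an aromatic substituent on the core, between compound 1 and compound 2, stays within the scatter.

The step from compound 1 to compound 4 in this assay is therefore expected to be small, a number 3.9 percentage points lower from compound 1 to compound 4 (within the scatter), with no clear direction beyond the scatter. Compound 4 is estimated to give 56%, in the range from 38% to 72%.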

Compound 4, a percentage reported as inhibition, at one concentration (the size of the read-out at that concentration, not a potency): 53.4%
For compound 4 the middle estimate is 2.6 percentage points above the measured one; the range from low to high includes it.
By their numbers in this assay, from the lowest: compound 3; then compounds 2, 4 and 1 (each within the scatter of the next).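

In this assay, among these compounds, putting thiophen-3-yl in place of furan-2-yl on the aromatic carbon between two ring nitrogen atoms gives a number 6.5 percentage points lower from compound 1 to compound 4 (within the scatter), the first step at this position with the rest of the molecule held the same. The position thus takes one five-membered aromatic ring with 1 hetero atom in place of another, sulfur for oxygen, with no difference that can be told from the scatter. No measurement at hand bears on the reason for this result.

As far as these compounds go, what an amine, a carboxylic acid or a longer chain would do at this position remains open, as the two groups compared here are closely alike in their counts. Whether compound 1 and compound 4 would also stay close in a full measure of potency is open too, as this assay reads a single concentration.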